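A few compounds are considered here, and "the series" means these few. Any claim that something is new, unique, unknown or untested is made for them only; others in the source may bear on it.

Measured in a functional assay on HL-60 cells (Homo sapiens) for cytotoxicity, read by MTT assay, with a stated time of 72 h; a higher number here means a weaker inhibitor, a lower number a stronger inhibitor:
- Compound 1 `Nc1cccc(Nc2nc3ccccc3nc2S(=O)(=O)c2ccccc2)c1`: 1750 nM
- Compound 2 `O=S(=O)(c1ccc(Br)cc1)c1nc2ccccc2nc1Nc1ccccc1`: 130 nM
- Compound 3 `Nc1ccc(Nc2nc3ccccc3nc2S(=O)(=O)c2ccc(Br)cc2)cc1`: 730 nM

Compound 3 has the second highest of these three numbers, with compound 1 higher and compound 2 lower. Compound 4 `Nc1cccc(Nc2nc3ccccc3nc2S(=O)(=O)c2ccc(Br)cc2)c1` differs from it by 3-aminophenyl in place of 4-aminophenyl on a nitrogen on an aromatic ring, with the change on a nitrogen on an aromatic ring. For the measured compounds named here, no measured step shifts the amino group. The nearest evidence is a 5.6-fold higher number from compound 2 to compound 3 (0.75 log units; beyond the scatter), which shows an amino group being added, not moved. Compound 1 also carries 3-aminophenyl and gives 1750 nM, but it lacks the bromine. In this assay, no change beyond the scatter is therefore expected. The expected step is a 1.1-fold higher number from compound 3 to compound 4 (0.04 log units; within the scatter). Compound 4 is estimated at 800 nM, with an expected range of 280 nM to 2000 nM.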

Compound 4, half-maximal inhibitory concentration: 1370 nM
Estimate against measurement, compound 4: 1.7-fold (0.23 log units) below, within the range that was stated.
By their numbers in this assay, from the lowest: compound 2; then compounds 3, 4 and 1 (each within the scatter of the next, the first and the last beyond it).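

In this assay, moving the amino group from 4-aminophenyl to 3-aminophenyl on the nitrogen gives a 1.9-fold higher number from compound 3 to compound 4 (0.27 log units; within the scatter), so the two placements are not told apart. With 3-aminophenyl in place, bromo gives a 1.3-fold lower number from compound 1 to compound 4 (0.11 log units; within the scatter), which also does not separate the pair. Adding the amino group to the unsubstituted phenyl of compound 2 gives an 11-fold higher number from compound 2 to compound 4 (1.02 log units; beyond the scatter), so it is the amino group's presence, not its placement, that produces a step beyond the scatter.

On these data alone, whether a hydroxyl or methoxy group there would give a similar step remains open. Nothing shown accounts for these steps.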